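Fluoro removal on the indole of a nitrile-bearing enone series

A few compounds are considered here, and "the series" means these few. Any claim that something is new, unique, unknown or untested is made for them only; others in the source may bear on it.

Measured so far:
compound 1 `N#C/C(=C\c1c[nH]c2cc(F)ccc12)C(=O)c1c[nH]c2cc(F)ccc12` gives > 50000 nM in a functional assay on MIA PaCa-2 cells (Homo sapiens) for cytotoxicity, read by WST assay, with a stated time of 48 h; on this read-out higher numbers stand for weaker inhibition and lower numbers for stronger inhibition
compound 2 `N#C/C(=C\c1c[nH]c2cc(F)ccc12)C(=O)c1c[nH]c2ccccc12` gives 31600 nM
compound 3 `COc1ccc(Cn2cc(/C=C(\C#N)C(=O)c3c[nH]c4cc(F)ccc34)c3ccccc32)cc1` gives 29400 nM

Compound 1 is recorded only as a limit of this assay, (the limit of > 50000 nM in this assay, at which 1 of the 3 values shown sits). Compound 2 differs from it by hydrogen in place of fluoro on an aromatic carbon; the step is an at least 1.5-fold lower number from compound 1 to compound 2 (0.19 log units; that floor lies within the scatter). Compound 3 carries a different core; the difference between the two cores is not broken down here. Its value and that of compound 2 lie within the scatter of each other.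

Compound 4 `COc1ccc(Cn2cc(/C=C(\C#N)C(=O)c3c[nH]c4ccccc34)c3ccccc32)cc1` is not yet measured. It differs from compound 3 by hydrogen in place of fluoro on an aromatic carbon, the same change as from compound 1 to compound 2. The earlier step from compound 1 to compound 2 gave an at least 1.5-fold lower number from compound 1 to compound 2 (0.19 log units; that floor lies within the scatter), so a step of similar or slightly larger size is expected from compound 3 to compound 4, namely a 1.3-fold lower number from compound 3 to compound 4 (0.13 log units; within the scatter). Compound 4 is thus expected to give about 22000 nM in this assay, likely between 8000 nM and 50000 nM.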

Compound 4, half-maximal inhibitory concentration: > 50000 nM
Compound 4 ended at the assay's limit; the forecaster's own chance of this, stated with the estimate: 15%; middle value at least 2.2-fold (0.35 log units) away from the limit.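

In this assay, hydrogen in place of fluoro on the core of compound 3 gives an at least 1.7-fold higher number from compound 3 to compound 4 (0.23 log units; that floor lies within the scatter). Compound 4 is recorded only as a limit, > 50000 nM. The change is thus neither shown to carry over from one core to the other nor shown to fail to do so, and the direction of the step on each core remains unsettled: the same change on two cores in this assay, an at least 1.5-fold lower number (0.19 log units; that floor lies within the scatter) from compound 1 to compound 2 and an at least 1.7-fold higher number (0.23 log units; that floor lies within the scatter) from compound 3 to compound 4; the limit leaves it open whether they differ

Still open, going by these compounds, is whether an amine or a carboxylic acid in place of the fluoro on the core of compound 3 would give a value clear of the limit in this assay. The compounds shown also leave open how such a group would behave on the core of compound 1.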